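Ester to ethylamide on a shared core

This account rests on a few compounds, and the source may have more. Where it says the series, first, only, none or still open, it means among the compounds named here.

Three measured compounds share one core and differ only in the group on the carbonyl. In an assay on isolated protein for inhibition of protein kinase C zeta type (Homo sapiens), with stated times of 1 h and 2.5 min, tested at 30 uM (a lower number here means less inhibition, a higher number more inhibition at the concentration tested (going by the name of the read-out)), compound 2 `COc1ccc(-c2csc(N)c2C(=O)OCc2cccc(C)c2)cc1OC` gives 67%, the highest of the three. Compound 1 `COc1ccc(-c2csc(N)c2C(=O)Oc2ccccc2)cc1OC` gives 48% in this assay, and compound 3 `COc1ccc(-c2csc(N)c2C(=O)OCc2ccc(C#N)cc2)cc1OC` gives 10%. The steps of a number 19 percentage points higher from compound 1 to compound 2 (beyond the scatter), a number 38 percentage points lower from compound 1 to compound 3 (beyond the scatter) and a number 57 percentage points lower from compound 2 to compound 3 (beyond the scatter) show that this part of the molecule shifts the read-out well beyond the scatter. Compound 4 `CCNC(=O)c1c(-c2ccc(OC)c(OC)c2)csc1N` carries ethylamino in place of (3-methylbenzyl)oxy on a carbonyl carbon. Among the measured compounds shown here, no measured step exchanges an oxygen-linked group for a nitrogen-linked one, so its direction is not fixed by the data. Every measured change there moved the number markedly, and a sizeable downward step a number 37 percentage points lower from compound 2 to compound 4 (beyond the scatter) is therefore expected. Compound 4 is estimated at 30%, within 5% to 60%.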

Compound 4, a percentage reported as inhibition, at one concentration (the size of the read-out at that concentration, not a potency): 50%
Compound 4: the middle estimate sits 20 percentage points below what was measured; measured number inside the range.
By their numbers in this assay, from the lowest: compound 3; then compounds 1 and 4 (each within the scatter of the next); then compound 2.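

In this assay, ethylamino on the carbonyl carbon gives a number 17 percentage points lower from compound 2 to compound 4 (beyond the scatter) and a number 2 percentage points higher from compound 1 to compound 4 (within the scatter), so this change costs inhibition against the (3-methylbenzyl)oxy group but not against the phenoxy group. Among these compounds, a group with no ring and a hydrogen-bond donor therefore reads level with compound 1, and an aromatic ring on the carbonyl is not needed for that level. Nothing measured here explains either step. Going by these compounds, it remains open whether a benzylamino group would match compound 2 or a longer chain on the amide nitrogen would shift the number. A free carboxylic acid at this carbonyl also remains untested in what is shown here.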